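Taking the ethynyl group off compound 1

The compounds below may be only part of what the source reports. "The series", "measured", "known", "first", "only" and "open" are said of these compounds alone.

Measured in a functional assay on B16 cells (Mus musculus) for cytotoxicity, read by MTT assay, with a stated time of 48 h; a lower number here means a stronger inhibitor, a higher number a weaker inhibitor:
- compound 1 `C#Cc1cccc(NC(=O)c2cn(Cc3ccccc3)nn2)c1`: 14500 nM
- compound 2 `C#Cc1cccc(NC(=O)c2cn(CC(=O)OCC)nn2)c1`: 91000 nM

Compound 1 holds the lower of these two numbers, which makes it the stronger inhibitor of the pair, though two compounds are a very small set. Compound 3 `O=C(Nc1ccccc1)c1cn(Cc2ccccc2)nn1` differs from compound 1 in one place, with hydrogen in place of ethynyl on an aromatic carbon.

Going by the values given here, only one measured step exists, a 6.3-fold higher number from compound 1 to compound 2 (0.80 log units; beyond the scatter). It changes a different part of the molecule, so it shows only how far a single change has moved the number in this assay, and says nothing direct about losing the ethynyl. Among the compounds with values here, no measured compound lacks that group, so the data fix no firm direction. Compound 1, at 14500 nM, is the lower of the two values, which gives a mild lean towards a higher number, with a step of similar or smaller size, and no real change remains possible. The expected step is a 1.7-fold higher number from compound 1 to compound 3 (0.22 log units; within the scatter). For compound 3 the estimate is 24000 nM, with an expected range from 8000 nM to 70000 nM.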

Compound 3, half-maximal inhibitory concentration: 93000 nM
Compound 3: the middle estimate sits 3.9-fold (0.59 log units) below what was measured; the whole stated range lies below it.
By their numbers in this assay, from the lowest: compound 1; then compounds 2 and 3 (each within the scatter of the next).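

In this assay, the ethynyl group now has a measured effect: replacing it with hydrogen gives a 6.4-fold higher number from compound 1 to compound 3 (0.81 log units; beyond the scatter) and so this place on the six-membered aromatic ring clearly counts, even though the group that leaves has only 2 heavy atoms. The one step known earlier, a 6.3-fold higher number from compound 1 to compound 2 (0.80 log units; beyond the scatter) changed a different part of the molecule, so there are now two single changes away from compound 1, at two separate places, and both raise the number beyond the scatter, with no compound shown going against that. Nothing measured here accounts for why losing the ethynyl group raises the number.

From the compounds shown here alone, it remains open whether the triple bond itself matters or whether almost any small group at this place would hold the number down, a question that an ethyl group, a nitrile or a methoxy group in the same place could begin to answer. Going by these compounds, it is also open whether taking the ethynyl group off compound 2 would move the number in the same direction and by a similar amount.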